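The compounds below may be only part of what the source reports. "The series", "measured", "known", "first", "only" and "open" are said of these compounds alone.

All three measured compounds were tested in a functional assay on 4T1 cells (Mus musculus) for cytotoxicity, read by MTT assay, with a stated time of 24 h; on this read-out lower numbers stand for stronger inhibition and higher numbers for weaker inhibition:

Compound 1, `O=C1/C(=C/c2ccccc2F)CN(C(=S)SCc2cn(Cc3ccccc3Cl)nn2)C/C1=C\c1ccccc1F`, gives 43600 nM.
Compound 2, `O=C1/C(=C/c2ccccc2F)CN(C(=S)SCc2cn(Cc3ccccc3F)nn2)C/C1=C\c1ccccc1F`, gives 30700 nM.
Compound 3, `COc1ccc(/C=C2\CN(Cc3cn(Cc4ccccc4Cl)nn3)C/C(=C\c3ccc(OC)cc3)C2=O)cc1`, gives 11400 nM.

Compounds 1 and 2 share one core and differ in a single place: fluoro in place of chloro on an aromatic carbon. In this assay the step between them, a 1.4-fold lower number from compound 1 to compound 2 (0.15 log units; within the scatter), is small enough to count as the ordinary spread of repeated measurements rather than a real change in potency.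

Compound 3 is built on a different core. How its core differs from that of compound 1 is not broken down here; what the numbers show is that compound 3 sits at the lowest value of the three, with the gap to compound 2 and the gap to compound 1 both larger than the usual scatter.

Compound 4, `COc1ccc(/C=C2\CN(Cc3cn(Cc4ccccc4F)nn3)C/C(=C\c3ccc(OC)cc3)C2=O)cc1`, has not yet been measured. It stands to compound 3 exactly as compound 2 stands to compound 1: fluoro in place of chloro on an aromatic carbon. The place of the change is described in the same words in both pairs, so this is the same change made on a second core.

Because the earlier step was a 1.4-fold lower number from compound 1 to compound 2 (0.15 log units; within the scatter), the step from compound 3 to compound 4 is expected to be similarly small, a 1.3-fold lower number from compound 3 to compound 4 (0.10 log units; within the scatter), with compound 3 as the anchor. On that basis compound 4 is estimated to give 9000 nM, expected to lie between 4000 nM and 20000 nM.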

Compound 4, half-maximal inhibitory concentration: 39400 nM
Compound 4: the middle estimate sits 4.4-fold (0.64 log units) below what was measured; the measured number lies above the stated range.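

In this assay, replacing the 2-chlorobenzyl group with a 2-fluorobenzyl group gives a 3.5-fold higher number from compound 3 to compound 4 (0.54 log units; beyond the scatter), so the swap that made no measurable difference on the first core makes a real difference on the second, and the two steps do not agree: the same change on two cores in this assay, a 1.4-fold lower number (0.15 log units; within the scatter) from compound 1 to compound 2 and a 3.5-fold higher number (0.54 log units; beyond the scatter) from compound 3 to compound 4, 4.9-fold (0.69 log units) apart, beyond the scatter of two such steps

This means that the effect of this change does not carry over between the two cores in this series: a step measured on the core of compound 1 would have been a poor guide to the step on the core of compound 3. What these two pairs do not show is which part of the cores is responsible for the disagreement, or how the same swap would behave on any third core.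

From the compounds shown here alone, it remains open whether a bromo or a methyl group on the same aromatic carbon would give numbers closer to those of the chloro compounds or the fluoro compounds on each core. Going by these compounds, it also remains open whether the higher number of compound 4 relative to compound 3 would appear in cell lines other than this one.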